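Working notes: from compound 2 to compound 3

This account rests on a few compounds, and the source may have more. Where it says the series, first, only, none or still open, it means among the compounds named here.

compound 1 (`O=C(Nc1ccc(C(F)(F)F)cc1)Nc1cc2ncncc2cc1OCc1cccc(F)c1`) gives 6300 nM
compound 2 (`O=C(Nc1cccc(Cl)c1)Nc1cc2ncncc2cc1OCc1cccc(Cl)c1`) gives 3500 nM

Both values come from a functional assay on GBM3 cells (Homo sapiens) for antiproliferative activity, read by WST assay, with a stated time of 72 h; a higher number here means a weaker inhibitor, a lower number a stronger inhibitor. Compound 2 (3500 nM) and compound 1 (6300 nM) lie within the scatter of each other, so the numbers do not separate them. Compound 3 (`O=C(Nc1ccc(C(F)(F)F)cc1)Nc1cc2ncncc2cc1OCc1cccc(Cl)c1`) is still unmeasured. It differs from compound 2 as follows: 4-(trifluoromethyl)phenyl in place of 3-chlorophenyl on an amide-type nitrogen. In words, this is 4-(trifluoromethyl)phenyl in place of 3-chlorophenyl on an amide-type nitrogen. For the measured compounds named here, no step between measured compounds is available as a guide. Compound 1, which also carries 4-(trifluoromethyl)phenyl on an amide-type nitrogen, gives 6300 nM, so no change beyond the scatter is expected in this assay. The estimate amounts to an expected 1.3-fold higher number from compound 2 to compound 3 (0.11 log units; within the scatter). For compound 3 the estimated value is 4500 nM, with an expected range from 1800 nM to 11000 nM.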

Compound 3, half-maximal inhibitory concentration: 5100 nM
Beside the measured number, compound 3's estimate is 1.1-fold (0.05 log units) below it, and the stated range covers the measured number.
By their numbers in this assay, from the lowest: compounds 2, 3 and 1 (each within the scatter of the next).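

In this assay, for the compounds shown here, 4-(trifluoromethyl)phenyl in place of 3-chlorophenyl on an amide-type nitrogen gives the first single-place reading at this position (a 1.5-fold higher number from compound 2 to compound 3 (0.16 log units; within the scatter)), and the numbers do not separate the two aryl groups. Going by these compounds alone, compound 3 also gives the first reading of chloro in place of fluoro on an aromatic carbon (a 1.2-fold lower number from compound 1 to compound 3 (0.09 log units; within the scatter)), so with 4-(trifluoromethyl)phenyl held constant, that exchange does not separate the compounds either. No measured evidence bears on the reason for either step.

The compounds shown leave open whether any group on the amide-type nitrogen moves the number beyond the scatter, since only these two substituted phenyl groups are covered there. An aminomethyl or carboxylic acid group on that phenyl ring, or a longer alkyl chain in its place, remains to be read.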